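The source may report more compounds than this note shows. Statements on the series, on what has been measured and on what is new or still open speak of the compounds shown alone.

Measured compounds:
- compound 2, `CCCC[C@]1(CC)CS(=O)(=O)c2ccc(NC(=O)OCc3ccccc3)cc2[C@@H](c2ccccc2)[C@H]1O`: 400 nM
- compound 1, `C=CCCCCCCCCOc1ccc2c(c1)S(=O)(=O)C[C@@](CC)(CCCC)[C@H](O)[C@@H]2c1ccccc1`: 16000 nM

The series rests on two measured compounds sharing one core. In an assay on cells for inhibition of ileal sodium/bile acid cotransporter (Homo sapiens) (a lower number here means a stronger inhibitor, a higher number a weaker inhibitor), compound 2 gives 400 nM, the lowest of the two numbers. Compound 1, in this assay, gives 16000 nM, a much higher number, beyond the scatter of the method. For the measured compounds named here, no single-point step between the two measured compounds can be read, as they differ in more than one place, so the two values only show that compound 2 stands far ahead of compound 1.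

Compound 3, `CCCC[C@]1(CC)CS(=O)(=O)c2ccc(NS(C)(=O)=O)cc2[C@@H](c2ccccc2)[C@H]1O`, has not yet been measured in this assay. It differs from compound 2 in one place: methylsulfonyl in place of benzyloxycarbonyl on a nitrogen on an aromatic ring. Going by the values given here, no measured pair shows what such a change does here, so the direction of the step is uncertain. With only the value of compound 2 as anchor, a moderate loss beyond the scatter is expected, amounting to a 3.0-fold higher number from compound 2 to compound 3 (0.48 log units; beyond the scatter). Compound 3 is therefore expected to give about 1200 nM, within a range from 300 nM to 6000 nM.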

Compound 3, half-maximal inhibitory concentration: 600 nM
The estimate for compound 3 lay 2.0-fold (0.30 log units) above the measured number, within the range that was stated.
By their numbers in this assay, from the lowest: compounds 2 and 3 (each within the scatter of the next); then compound 1.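

On the nitrogen on an aromatic ring, methylsulfonyl in place of benzyloxycarbonyl gives a 1.5-fold higher number from compound 2 to compound 3 (0.18 log units; within the scatter) in this assay. The earlier compounds shown here offered no step at this place, and this first one shows that the benzyloxycarbonyl group, with 10 heavy atoms and a six-membered aromatic ring of carbon only, can be exchanged for methylsulfonyl, with 4 heavy atoms and no ring, while compound 2 and compound 3 remain indistinguishable in this assay. The ring and most of the heavy atoms of the benzyloxycarbonyl group are therefore not needed to hold the number in this range, though no measurement available here explains why the two groups read alike.

As far as these compounds go, a single pair cannot show how far this holds, so it remains open whether the free amine, an acetyl group, or a longer chain in place of the methyl of the methylsulfonyl group would also leave the number unchanged. From the compounds shown here alone, it is equally open what a carboxylic acid or a tertiary amine carried at the end of such a chain would do at this nitrogen in this assay.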